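Removing the ring methyl from compound 2: expected cytotoxicity

The compounds below may be only part of what the source reports. "The series", "measured", "known", "first", "only" and "open" are said of these compounds alone.

The series shares a nitro-bearing five-membered aromatic ring with 1 nitrogen joined through a carbonyl hydrazide to a urea or thiourea. Compound 1 `COc1ccc(NC(=S)NNC(=O)c2cc([N+](=O)[O-])c[nH]2)cc1` carries a thiourea to a methoxyphenyl group; compound 2 `Cn1cc([N+](=O)[O-])cc1C(=O)NNC(=O)NCc1ccco1` carries a urea to a furanylmethyl group; compound 3 `Cn1cc([N+](=O)[O-])cc1C(=O)NNC(=S)Nc1ccc(Cl)cc1` carries a thiourea to a chlorophenyl group. In an ADME assay on Vero cells (Chlorocebus sabaeus) for cytotoxicity, read by MTT assay, with a stated time of 72 h (a lower number here means a stronger inhibitor, a higher number a weaker inhibitor), compound 1 gives 331000 nM. In this assay compound 2 gives 482000 nM, and in this assay compound 3 gives 210000 nM. Compound 2 and compound 1 lie within the scatter of each other, whereas the number for compound 2 stands higher than that for compound 3 by a margin beyond the scatter.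

Compound 4 `O=C(NCc1ccco1)NNC(=O)c1cc([N+](=O)[O-])c[nH]1` has not been measured in this assay. It differs from compound 2 in one place: hydrogen in place of methyl on an aromatic nitrogen. For the measured compounds named here, no pair of measured compounds differs in this one place alone, so no measured step shows what this change does; compound 1 and compound 3 also differ elsewhere. The account therefore expects a step from compound 2 to compound 4 of a 1.2-fold lower number from compound 2 to compound 4 (0.08 log units; within the scatter), that is, none beyond the scatter. For compound 4 in this assay the estimate is 400000 nM, within a range of 200000 nM to 800000 nM.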

Compound 4, half-maximal inhibitory concentration: 443000 nM
The estimate for compound 4 lay 1.1-fold (0.04 log units) below the measured number; low and high end bracket the measured number.
By their numbers in this assay, from the lowest: compounds 3, 1, 4 and 2 (each within the scatter of the next, the first and the last beyond it).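

In this assay, for the compounds shown here, the step at this position reads a 1.1-fold lower number from compound 2 to compound 4 (0.04 log units; within the scatter) and gives the first direct reading of hydrogen in place of methyl on the aromatic nitrogen, since no earlier pair differed in this one place alone. With the urea and the furanylmethyl group held constant, the methyl on this nitrogen can leave without any change in the number that can be told from the usual scatter, so for this pair the methyl makes no readable difference to the cytotoxicity result. No measurement given here offers an explanation for this result.

The compounds shown leave open whether the same swap would read the same way on the thiourea compounds, such as compound 3 with its chlorophenyl group, since this single step comes from one urea with one furanylmethyl group. They also leave open what a longer chain such as propyl, or a chain ending in an amine or a carboxylic acid, would do on this aromatic nitrogen in this assay where only methyl and hydrogen have been compared.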